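Series notes: aryl variation on the shared core, antiproliferative read-out

The source may report more compounds than this note shows. Statements on the series, on what has been measured and on what is new or still open speak of the compounds shown alone.

Two members of the series have been measured. Compound 1 `COc1ccc2c(OCc3nnc4sc(-c5cnn(C)c5)nn34)ccnc2c1` carries a 1-methyl-1H-pyrazol-4-yl group and in a functional assay on EBC-1 cells (Homo sapiens) for antiproliferative activity, with a stated time of 72 h (a lower number here means a stronger inhibitor, a higher number a weaker inhibitor), compound 1 gives 88 nM. Compound 2 `COc1ccc2c(OCc3nnc4sc(-c5ccncc5)nn34)ccnc2c1` carries pyridin-4-yl in its place, and in this assay compound 2 gives 289 nM. For the measured compounds named here, the one measured step, a 3.3-fold higher number from compound 1 to compound 2 (0.52 log units; beyond the scatter), lies beyond the scatter, so compound 2 stands as the higher of the two numbers, with compound 1 the nearest and lower.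

Compound 3 `COc1cccc(-c2nn3c(COc4ccnc5cc(OC)ccc45)nnc3s2)c1` is not yet measured. It differs from compound 2 by 3-methoxyphenyl in place of pyridin-4-yl on an aromatic carbon. Going by the values given here, the only measured step at this position is the one from compound 1 to compound 2, and it was modest; the change to compound 3 exchanges one six-membered aromatic ring with one acceptor for another ring of the same size and acceptor count, with no measured precedent for a carbon-only ring here. The expectation in this assay is therefore a step within or close to the scatter from compound 2, in either direction, expressed as a 1.2-fold higher number from compound 2 to compound 3 (0.08 log units; within the scatter). Compound 3 is estimated at 350 nM, with a plausible range from 120 nM to 1000 nM.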

Compound 3, half-maximal inhibitory concentration: 472 nM
Compound 3: the middle estimate sits 1.3-fold (0.13 log units) below what was measured, and the stated range covers the measured number.
By their numbers in this assay, from the lowest: compound 1; then compounds 2 and 3 (each within the scatter of the next).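

In this assay the step of a 1.6-fold higher number from compound 2 to compound 3 (0.21 log units; within the scatter) shows that 3-methoxyphenyl and pyridin-4-yl cannot be told apart on this aromatic carbon, so a ring of carbon only, with two more heavy atoms, is tolerated as well as the ring with one hetero atom. The step of a 5.4-fold higher number from compound 1 to compound 3 (0.73 log units; beyond the scatter) is now a second one beyond the scatter away from 1-methyl-1H-pyrazol-4-yl, alongside a 3.3-fold higher number from compound 1 to compound 2 (0.52 log units; beyond the scatter) in the same direction, so among these three compounds compound 1 holds the lowest number and neither group with a six-membered aromatic ring matches it, with no compound here going against that. Nothing measured for the series accounts for this difference or for the lack of one between compound 2 and compound 3.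

Still open, as far as these compounds go, is whether a plain phenyl, or a phenyl carrying an amine or a carboxylic acid, on this aromatic carbon would sit with compound 3 or come closer to compound 1. From the compounds shown here alone, all three compounds share one core and one read-out, so how these steps would carry over to a different core or to a test outside this assay remains unknown.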